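The source may hold more compounds than are shown below. What is called first, only, known or untested is meant among the compounds shown, and "the series" means these compounds.

Measured compounds:
Compound 1, `CC(=O)n1cc(/C=C(/C(=O)O)c2ccccc2)c2cc(OCc3ccccc3)ccc21` — 55500 nM
Compound 2, `COc1ccc(Cn2cc(/C=C(/C(=O)O)c3ccccc3)c3cc(OCc4ccccc4)ccc32)cc1` — 97000 nM

Both compounds were tested in a functional assay on KB cells (Homo sapiens) for cytotoxicity, read by MTT assay, with a stated time of 72 h; on this read-out lower numbers stand for stronger inhibition and higher numbers for weaker inhibition. Among the measured compounds shown here, compound 2 stands at the highest of the two numbers, with compound 1 nearest; the only step measured so far, a 1.7-fold higher number from compound 1 to compound 2 (0.24 log units; within the scatter), lies within the scatter, so the two compounds cannot be told apart on this read-out. Compound 3, `O=C(O)/C(=C/c1c[nH]c2ccc(OCc3ccccc3)cc12)c1ccccc1`, is the next compound to be measured. It differs from compound 2 in one place: hydrogen in place of 4-methoxybenzyl on an aromatic nitrogen, that is, the group on the aromatic nitrogen of the shared core is removed altogether. For the measured compounds named here, no measured step describes this exact change. Going by the values given here, the one measured step, from an acetyl group to a 4-methoxybenzyl group on the same nitrogen, did not move the number beyond the scatter, which gives little reason to expect a large shift when the nitrogen carries only hydrogen. The number for compound 3 in this assay is therefore expected to stay close to that of compound 2, the step of a 1.5-fold lower number from compound 2 to compound 3 (0.17 log units; within the scatter) being a modest one. Compound 3 is estimated at 65000 nM, with a range from 20000 nM to 200000 nM.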

Compound 3, half-maximal inhibitory concentration: 55500 nM
Compound 3: the middle estimate sits 1.2-fold (0.07 log units) above what was measured; the measured number falls inside the stated range.
By their numbers in this assay, from the lowest: compounds 1, 3 and 2 (each within the scatter of the next).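

In this assay, hydrogen in place of 4-methoxybenzyl on the aromatic nitrogen gives a 1.7-fold lower number from compound 2 to compound 3 (0.24 log units; within the scatter) and hydrogen in place of acetyl gives no change at the digits printed from compound 1 to compound 3 (within the scatter) on the same read-out. Among the compounds shown here, the earlier pair compared only two groups on this nitrogen, whereas these steps add the case with no heavy atom there at all, and acetyl, 4-methoxybenzyl and hydrogen still cannot be told apart. No supporting data explain why these three compounds cannot be separated.

From the compounds shown here alone, all three compounds share the same core, with the carboxylic acid, the phenyl group and the benzyloxy group unchanged, so the contribution of each of these parts to the cytotoxicity reading remains open, for example what an amide or a methyl ester in place of the carboxylic acid would give. Going by these compounds, it also remains open whether any group on the aromatic nitrogen can move the number beyond the scatter, such as a longer chain ending in an amine.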